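Halogen placement on the aryl ring of the shared core

The compounds below may be only part of what the source reports. "The series", "measured", "known", "first", "only" and "open" are said of these compounds alone.

Measured compounds:
compound 1 `O=c1c2ccccc2[se]n1-c1nnc(-c2ccc(Br)cc2)s1` — 68200 nM
compound 2 `O=c1c2ccccc2[se]n1-c1nnc(-c2ccc(F)cc2)s1` — 42900 nM

Both compounds were measured in a functional assay on SSMC-7721 cells (Homo sapiens) for antiproliferative activity, read by CCK-8 assay, with a stated time of 48 h; on this read-out lower numbers stand for stronger inhibition and higher numbers for weaker inhibition. Among the measured compounds shown here, compound 2 gives the lowest of the two numbers, but the only measured step, a 1.6-fold lower number from compound 1 to compound 2 (0.20 log units; within the scatter), lies within the scatter, so the two values cannot be told apart.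

Compound 3 `O=c1c2ccccc2[se]n1-c1nnc(-c2ccccc2Cl)s1` has not yet been measured. It differs from compound 2 by 2-chlorophenyl in place of 4-fluorophenyl on an aromatic carbon. For the measured compounds named here, the one measured step that bears on this change is the halogen swap on the same aryl ring, a 1.6-fold lower number from compound 1 to compound 2 (0.20 log units; within the scatter), which showed no change beyond the scatter. Going by the values given here, the move of the halogen from the 4-position to the 2-position of the phenyl ring has no measured counterpart in this set, so nothing in the data speaks for a step in either direction. The expectation for compound 3 in this assay is therefore a number close to that of compound 2, with the step of a 1.2-fold higher number from compound 2 to compound 3 (0.07 log units; within the scatter) expected to stay within the scatter. Compound 3 is estimated at 50000 nM, with a range of 15000 nM to 160000 nM.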

Compound 3, half-maximal inhibitory concentration: 40200 nM
Compound 3: middle estimate off by 1.2-fold (0.09 log units), on the high side; the measured number falls inside the stated range.
By their numbers in this assay, from the lowest: compounds 3, 2 and 1 (each within the scatter of the next).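

The swap to 2-chlorophenyl on the aromatic carbon next to the ring nitrogen and the ring sulfur changes both the halogen and its place on the phenyl ring, yet it gives a 1.1-fold lower number from compound 2 to compound 3 (0.03 log units; within the scatter) in this assay, and the comparison with the bromo compound gives a 1.7-fold lower number from compound 1 to compound 3 (0.23 log units; within the scatter). Unlike the earlier halogen swap, these steps include a change in where the halogen sits, and all three compounds still remain within the scatter of one another, so this set of halogenated phenyl groups cannot be separated on this read-out. No supporting data bear on why these values stay together.

Halogen identity and halogen place change together between compound 2 and compound 3, so a 4-chlorophenyl group would be needed to read the effect of either change alone. Going by these compounds, it also remains open whether an unsubstituted phenyl, or a phenyl carrying an amine or a carboxylic acid, would give a number beyond the scatter of these three compounds.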